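Aldosterone synthase series: amide in place of sulfonamide

The compounds below may be only part of what the source reports. "The series", "measured", "known", "first", "only" and "open" are said of these compounds alone.

Compound 1 `CC(=O)N1CC[C@H](Oc2cncc(N3C(=O)c4ccc(Cl)cc4C3(C)C)c2)C1` and compound 2 `CCS(=O)(=O)NCc1cncc(N2C(=O)c3ccc(Cl)cc3C2(C)C)c1` share a core and differ only in the group on one aromatic carbon. In an assay on cells for inhibition of cytochrome P450 11B2, mitochondrial (Homo sapiens), read by HTRF (a higher number here means a weaker inhibitor, a lower number a stronger inhibitor), compound 1 gives 7 nM, and compound 2 gives 92 nM. Within the data shown here, the one step measured so far, a 13-fold higher number from compound 1 to compound 2 (1.12 log units; beyond the scatter), places compound 2 as the weaker of the two, the highest number of the pair.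

Compound 3 `Cc1cccnc1C(=O)NCc1cncc(N2C(=O)c3ccc(Cl)cc3C2(C)C)c1` keeps the amine nitrogen and its chain of compound 2 and changes only the group attached there: (3-methylpyridin-2-yl)carbonyl in place of ethylsulfonyl on an amine nitrogen. Among the measured compounds shown here, no measured step exchanges one group on that nitrogen for another; the only step in hand, a 13-fold higher number from compound 1 to compound 2 (1.12 log units; beyond the scatter), replaces the whole side chain and so bears on this change only loosely, in that the acetyl-bearing compound 1 is the stronger inhibitor and the ethylsulfonyl-bearing compound 2 the weaker one. A modest recovery toward the number of compound 1 is therefore expected, but not a full return. Compound 3 is estimated at 40 nM in this assay, with a range of 10 nM to 150 nM, which amounts to an expected step of a 2.3-fold lower number from compound 2 to compound 3 (0.36 log units; beyond the scatter).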

Compound 3, half-maximal inhibitory concentration: 9 nM
The estimate for compound 3 lay 4.4-fold (0.65 log units) above the measured number; measured number outside the range, below it.
By their numbers in this assay, from the lowest: compounds 1 and 3 (each within the scatter of the next); then compound 2.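

The exchange of ethylsulfonyl for (3-methylpyridin-2-yl)carbonyl on the amine nitrogen gives a 10-fold lower number from compound 2 to compound 3 (1.01 log units; beyond the scatter) in this assay, so the group on that nitrogen alone can produce a large step, which the earlier pair, differing in the whole side chain, could not show. The saturated chain carbon on that nitrogen stays the same, so the high number of compound 2 does not follow from this chain as such: with the new group, compound 3 lies within the scatter of compound 1, which carries a different side chain. Nothing in the available data explains the step, and this single change alters both the group type and the ring count at once.

Still open, going by these compounds, is which part of the entering group carries the step: a plain benzoyl or an unsubstituted pyridinylcarbonyl on the same nitrogen would separate the ring nitrogen from the methyl. Also open, on these data alone, is whether a smaller acetyl, a urea or a carbamate on that nitrogen would stay within the scatter of compound 3 in this assay.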